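Amide aryl swap: compound 3 to compound 4

A few compounds are considered here, and "the series" means these few. Any claim that something is new, unique, unknown or untested is made for them only; others in the source may bear on it.

Three compounds of the series have numbers in a toxicity assay on HepG2 cells (Homo sapiens) for inhibition, read by CellTiter-Glo, with a stated time of 48 h; on this read-out lower numbers stand for stronger inhibition and higher numbers for weaker inhibition. In this assay compound 1 `Cc1cc(C)cc(NC(=O)COc2cc(C)nc3ccc(F)cc23)c1` gives 63100 nM, compound 2 `COc1ccc2nc(C)cc(NCC(=O)Nc3cc(C)cc(C)c3)c2c1` gives 6310 nM, and compound 3 `COc1ccc2nc(C)cc(OCC(=O)Nc3ccccc3)c2c1` gives 39800 nM. Among these three numbers compound 3 stands second highest. Its nearest neighbour is compound 1, whose number sits within the usual scatter of that of compound 3, so no order between the two can be read. Compound 2 is the furthest, its lower number lying beyond the scatter.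

Compound 4 `COc1ccc2nc(C)cc(OCC(=O)Nc3cccnc3)c2c1` has not been measured in this assay. It differs from compound 3 by pyridin-3-yl in place of phenyl on an amide-type nitrogen. Going by the values given here, no pair of measured compounds shows this change, so the size of its effect is not known from the series. The step is expected to be small, toward a higher number or none beyond the scatter. Compound 4 is expected to give about 50000 nM in this assay, with a range from 18000 nM to 140000 nM. The expected step of a 1.3-fold higher number from compound 3 to compound 4 (0.10 log units; within the scatter) is thus estimated to remain near the scatter.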

Compound 4, half-maximal inhibitory concentration: > 100000 nM
Compound 4 gave a limit, no number; the forecaster's own chance of this, stated with the estimate: 25%; middle value at least 2.0-fold (0.30 log units) from the limit.
By their numbers in this assay, from the lowest: compound 2; then compounds 3 and 1 (each within the scatter of the next). At a limit, above all of these: compound 4.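

In this assay compound 4 gives > 100000 nM, which is a limit of the assay and not a number. Going by these compounds alone, until now no pair of compounds isolated a change on the amide-type nitrogen, and pyridin-3-yl in place of phenyl, with the heavy-atom count unchanged, now gives an at least 2.5-fold higher number from compound 3 to compound 4 (0.40 log units; beyond the scatter), so this position responds in the direction of weaker inhibition. The step has a lower bound only, and its full size cannot be read: the limit of > 100000 nM in this assay, at which 1 of the 4 values shown sits.

The compounds shown leave open whether pyridin-3-yl gives a step of this kind on the core of compound 1 or the core of compound 2. They also leave open how a pyridin-4-yl ring, or a phenyl ring carrying a carboxylic acid or an amine, would read at this position.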